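The source may hold more compounds than are shown below. What is called first, only, known or untested is meant among the compounds shown, and "the series" means these compounds.

Compound 1 `COc1ccc(-c2cc(=O)c3c(OC)cc(OC)cc3[nH]2)cc1` and compound 2 `COc1ccc(-c2cc(=O)c3c(OC)cc(OC)cc3n2S(=O)(=O)c2ccc(Cl)cc2)cc1` share one core and differ only on the aromatic nitrogen. In an ADME assay on BJ cells (Homo sapiens) for antiproliferative activity, with a stated time of 72 h (on this read-out lower numbers stand for an effect already at smaller amounts and higher numbers for an effect only at larger amounts of compound), compound 1 reaches only a limit, > 62000 nM. In this assay compound 2 likewise reaches only a limit, > 34400 nM. The step that the two limits leave unreadable from compound 1 to compound 2 stays unreadable because the limit of > 34400 nM in this assay, at which 1 of the 2 values shown sits, and the limit of > 62000 nM in this assay, at which 1 of the 2 values shown sits, hold both of its ends. Compound 3 `COc1ccc(-c2cc(=O)c3c(OC)cc(OC)cc3n2S(=O)(=O)c2ccc(C)cc2)cc1` differs from compound 2 by methyl in place of chloro on an aromatic carbon. Among the compounds with values here, no measured step bears on this change, so compound 3 is expected to show a step that the limit leaves unreadable from compound 2 to compound 3 and to remain at a limit. The value expected for compound 3 in this assay is 40000 nM, between 15000 nM and 110000 nM.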

Compound 3, half-maximal effective concentration: > 44800 nM
Compound 3 was reported as a limit (the forecaster's own chance of this, stated with the estimate: 75%); middle value at least 1.1-fold (0.04 log units) away from the limit.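

Within the data shown here, no step among compound 1, compound 2 and compound 3 can be read in this assay, since each is reported only as a limit. The compounds shown leave open whether (4-chlorophenyl)sulfonyl or (4-methylphenyl)sulfonyl changes the effect at all.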